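The source may report more compounds than this note shows. Statements on the series, on what has been measured and on what is new or still open speak of the compounds shown alone.

Compound 1 `CC(C)[C@H](NC(=O)CCN(C)C)c1cccc(F)c1N1CCN(C(=O)[C@@H]2CN(C(C)C)C[C@H]2c2ccc(Cl)cc2)CC1` gives 5.3 nM in an assay on HEK293 cells for displacement of a labelled ligand from Melanocortin receptor 4 (Homo sapiens); a lower number here means a stronger inhibitor, a higher number a weaker inhibitor. Compound 2 `CC(C)[C@H](NC(=O)CCN(C)C)c1cccc(F)c1N1CCN(C(=O)[C@@H]2CN(C(C)C)C[C@H]2c2cc(F)ccc2F)CC1` gives 2050 nM in this assay, and compound 3 `CC(C)[C@H](NC(=O)CCN(C)C)c1cccc(F)c1N1CCN(C(=O)[C@@H]2CN(C(C)C)C[C@H]2c2cccc(Cl)c2)CC1` gives 370 nM. Compound 3 thus stands second highest of the three numbers: the step of a 70-fold higher number from compound 1 to compound 3 (1.84 log units; beyond the scatter) is large, while the step of a 5.5-fold lower number from compound 2 to compound 3 (0.74 log units; beyond the scatter) is modest. Compound 4 `CC(C)[C@H](NC(=O)CCN(C)C)c1cccc(F)c1N1CCN(C(=O)[C@@H]2CN(C(C)C)C[C@H]2c2cc(F)cc(F)c2)CC1` differs from compound 3 by 3,5-difluorophenyl in place of 3-chlorophenyl on a saturated ring carbon. Going by the values given here, three measured steps bear on changes of the group on the saturated ring carbon: a 390-fold higher number from compound 1 to compound 2 (2.59 log units; beyond the scatter), a 70-fold higher number from compound 1 to compound 3 (1.84 log units; beyond the scatter) and a 5.5-fold lower number from compound 2 to compound 3 (0.74 log units; beyond the scatter). Both departures from 4-chlorophenyl raised the number heavily, and compound 2 with 2,5-difluorophenyl gave a higher number than compound 3 with 3-chlorophenyl. Whether 3,5-difluorophenyl behaves like 2,5-difluorophenyl is not shown by any measured pair, so a modest rise in the number, or no change beyond the scatter, is expected in this assay. Compound 4 is therefore estimated at 800 nM in this assay, with a range of 200 nM to 3000 nM. The expected step is a 2.2-fold higher number from compound 3 to compound 4 (0.33 log units; beyond the scatter).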

Compound 4, inhibition constant: 7800 nM
Compound 4: the middle estimate sits 9.8-fold (0.99 log units) below what was measured, outside the stated range (above it).
By their numbers in this assay, from the lowest: compound 1; then compound 3; then compound 2; then compound 4.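

In this assay, 3,5-difluorophenyl gives the highest number of the series, so the third departure from 4-chlorophenyl also raises the number and does so the most (a 1500-fold higher number from compound 1 to compound 4 (3.17 log units; beyond the scatter)). The exchange of 3-chlorophenyl for 3,5-difluorophenyl is large (a 21-fold higher number from compound 3 to compound 4 (1.32 log units; beyond the scatter)), and the two difluorophenyl isomers are also separated beyond the scatter (a 3.8-fold higher number from compound 2 to compound 4 (0.58 log units; beyond the scatter)), so at this saturated ring carbon the placement of the two fluorines matters, not just their presence. Nothing on hand explains these steps.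

Still open, going by these compounds, is whether the low number of compound 1 depends on chlorine itself, or whether a single bromine, fluorine or methyl group in the same place on the phenyl would serve as well. Unsubstituted phenyl would show what any substituent adds at this position.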